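The compounds below may be only part of what the source reports. "The series", "measured", "known", "first", "only" and "open" are said of these compounds alone.

Working notes on the series.

The shared core of compound 1 `CC1=C(C(=O)OC(C)c2ccccc2)C(c2csc(-c3ccc(Cl)cc3)n2)C(C(=O)OC(C)c2ccccc2)=C(C)N1` carries two 1-phenylethyl esters, and in an assay on isolated protein for antagonist activity at Voltage-dependent L-type calcium channel subunit alpha-1C (Cavia porcellus), with a stated time of 15 min (on this read-out lower numbers stand for stronger inhibition and higher numbers for weaker inhibition), compound 1 gives 400000 nM. Compound 2 `CCOC(=O)C1=C(C)NC(C)=C(C(=O)OC)C1c1csc(-c2ccc(Cl)cc2)n1` pairs an ethyl ester with a methyl ester; in this assay compound 2 gives 22000 nM. Compound 3 `CCOC(=O)C1=C(C)NC(C)=C(C(=O)OC2CCCCC2)C1c1csc(-c2ccc(Cl)cc2)n1` keeps the ethyl ester and replaces methyl with cyclohexyl; in this assay compound 3 gives 100000 nM, the second highest of the three numbers, with compound 1 nearest and compound 2 furthest. Among the measured compounds shown here, the one measured single-point step, a 4.5-fold higher number from compound 2 to compound 3 (0.66 log units; beyond the scatter), shows a larger group on that oxygen raising the number.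

Compound 4 `CCOC(=O)C1=C(C)NC(C)=C(C(=O)OC(C)c2ccccc2)C1c1csc(-c2ccc(Cl)cc2)n1` differs from compound 3 by 1-phenylethyl in place of cyclohexyl on an oxygen next to a carbonyl group. For the measured compounds named here, no measured step bears directly on this exchange; the only guides are the step from compound 2 to compound 3 and the position of compound 1, whose two 1-phenylethyl esters go with the highest number of the set. A small rise, or no step beyond the scatter, is therefore expected in this assay, with the step estimated as a 1.5-fold higher number from compound 3 to compound 4 (0.18 log units; within the scatter). Compound 4 is expected to give about 150000 nM, in the range 40000 nM to 500000 nM.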

Compound 4, half-maximal inhibitory concentration: 13800 nM
For compound 4 the middle estimate is 11-fold (1.04 log units) above the measured one; the measured number lies below the stated range.
By their numbers in this assay, from the lowest: compounds 4 and 2 (each within the scatter of the next); then compound 3; then compound 1.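

On this oxygen next to a carbonyl group, the rise seen with cyclohexyl does not extend to every larger group: in this assay, 1-phenylethyl in place of cyclohexyl gives a 7.2-fold lower number from compound 3 to compound 4 (0.86 log units; beyond the scatter), and 1-phenylethyl in place of methyl gives a 1.6-fold lower number from compound 2 to compound 4 (0.20 log units; within the scatter), so compound 3 goes against compound 4 in any simple link between group size and the number. The other ester also counts, since ethyl in compound 4 in place of the second 1-phenylethyl ester of compound 1 gives a 29-fold lower number from compound 1 to compound 4 (1.46 log units; beyond the scatter), so one 1-phenylethyl ester goes with a far lower number than two. No outside evidence bears on these steps.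

Open, going by these compounds, is whether the aromatic ring or the branched carbon of 1-phenylethyl goes with the lower number, a question a benzyl ester would separate. Also open, on these data alone, is how an ester chain ending in an amine would read at this oxygen.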